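The source may report more compounds than this note shows. Statements on the series, on what has been measured and on what is new or still open speak of the compounds shown alone.

In a functional assay on the whole organism for antagonist activity, with Mus musculus as the target (on this read-out lower numbers stand for an effect already at smaller amounts and higher numbers for an effect only at larger amounts of compound), compound 1 `CC(C#CCn1ccnc1)N1CCCC1=O` gives 3.7 mg/kg. Compound 2 `Cc1cncn1CC#CC(C)N1CCCC1=O` carries methyl in place of hydrogen on an aromatic carbon and in this assay gives 2.5 mg/kg, a step of a 1.5-fold lower number from compound 1 to compound 2 (0.17 log units; within the scatter). Compound 3 `CCOC(=O)N(C)CC#CCn1ccnc1` rests on a different core; the difference between the two cores is not broken down here. In this assay compound 3 gives 97 mg/kg, a number well away from those of compound 1 and compound 2. Compound 4 `CCOC(=O)N(C)CC#CCn1cncc1C` carries methyl in place of hydrogen on an aromatic carbon on the core of compound 3; the place is described in the same words as for compound 2, so the change is the same. The step of a 1.5-fold lower number from compound 3 to compound 4 (0.17 log units; within the scatter) is expected to be small, because the measured 1.5-fold lower number from compound 1 to compound 2 (0.17 log units; within the scatter) stayed within the scatter. Compound 4 is accordingly estimated at 65 mg/kg in this assay, with a likely range from 30 mg/kg to 150 mg/kg.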

Compound 4, dose for half-maximal effect: 66 mg/kg
The estimate for compound 4 lay 1.0-fold (0.01 log units) below the measured number; the measured number falls inside the stated range.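

In this assay, methyl in place of hydrogen on an aromatic carbon gives a 1.5-fold lower number from compound 3 to compound 4 (0.17 log units; within the scatter). Carried from the core of compound 1 to the core of compound 3, the change keeps its size: the same change on two cores in this assay, a 1.5-fold lower number (0.17 log units; within the scatter) from compound 1 to compound 2 and a 1.5-fold lower number (0.17 log units; within the scatter) from compound 3 to compound 4, 1.0-fold (0.00 log units) apart, within the scatter of two such steps

Among these compounds, this shows only that the step stays small on these two cores; as both steps lie within the scatter, it does not establish a real effect of the methyl, and it says nothing about other cores.

The compounds shown leave open whether an ethyl group or a chlorine atom at this place would also stay within the scatter. From the compounds shown here alone, whether a step beyond the scatter would carry across these two cores also remains open.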